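This account rests on a few compounds, and the source may have more. Where it says the series, first, only, none or still open, it means among the compounds named here.

Compound 3 `CN(C(=O)NC(=O)c1ccc(C(F)(F)F)cc1)c1nc(C(F)(F)F)c(C(=O)N/N=C/c2ccc(C(F)(F)F)cc2)s1` stands at the edge of what a functional assay on A549 cells (Homo sapiens) for inhibition, read by MTT assay, with a stated time of 72 h (a higher number here means a weaker inhibitor, a lower number a stronger inhibitor), can report: in this assay compound 3 gives > 100 ug/mL, which is a limit of the assay and not a number (the limit of > 100 ug/mL in this assay, at which 1 of the 3 values shown sits). Compound 2 `CN(C(=O)NC(=O)c1ccc(Cl)cc1Cl)c1nc(C(F)(F)F)c(C(=O)N/N=C/c2ccc(C(F)(F)F)cc2)s1` in this assay gives 9.4 ug/mL. Among the compounds with values here, the single measured step, an at least 10-fold higher number from compound 2 to compound 3 (1.02 log units; beyond the scatter), shows that the (4-(trifluoromethyl)phenyl)carbonyl is the weaker of the two acyl groups tested on this core. Within the data shown here, compound 1 `Cc1nc(N(C)C(=O)NC(=O)c2c(F)cccc2F)sc1C(=O)N/N=C/c1ccc(C(F)(F)F)cc1` carries the 2,6-difluorophenyl group on a different core, and in this assay compound 1 gives 60.5 ug/mL; no single step joins it to compound 3, so its value can only be set beside the others.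

Compound 4 `CN(C(=O)NC(=O)c1c(F)cccc1F)c1nc(C(F)(F)F)c(C(=O)N/N=C/c2ccc(C(F)(F)F)cc2)s1` has not yet been measured. Its change from compound 3 is 2,6-difluorophenyl in place of 4-(trifluoromethyl)phenyl on a carbonyl carbon. This is not the same change as the measured step, yet that step was large and beyond the scatter, with weaker inhibition when 4-(trifluoromethyl)phenyl entered; its departure here is therefore expected to move this assay toward lower numbers, and compound 1, with the same entering group, gives 60.5 ug/mL, which points the same way. Compound 4 is thus expected to give 40 ug/mL, between 15 ug/mL and 100 ug/mL. The expected step of an at least 2.5-fold lower number from compound 3 to compound 4 (0.39 log units; beyond the scatter) is a drop from the limit, beyond the scatter.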

Compound 4, half-maximal inhibitory concentration: 40.1 ug/mL
Estimate against measurement, compound 4: 1.0-fold (0.00 log units) below; low and high end bracket the measured number.
By their numbers in this assay, from the lowest: compound 2; then compounds 4 and 1 (each within the scatter of the next). At a limit, above all of these: compound 3.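

On the shared core, the place on the carbonyl carbon whose other neighbour is the amide-type nitrogen now shows a graded response rather than a single contrast, for 2,6-difluorophenyl does not reach what 2,4-dichlorophenyl gives in this assay, with a 4.3-fold higher number from compound 2 to compound 4 (0.63 log units; beyond the scatter). Within the data shown here, the gain over 4-(trifluoromethyl)phenyl, an at least 2.4-fold lower number from compound 3 to compound 4 (0.39 log units; beyond the scatter), is measured against compound 3, whose value is a limit of the assay and not a number: the limit of > 100 ug/mL in this assay, at which 1 of the 4 values shown sits. The new compound also links the two cores for the first time: with 2,6-difluorophenyl held constant, trifluoromethyl in place of methyl on an aromatic carbon gives a 1.5-fold lower number from compound 1 to compound 4 (0.18 log units; within the scatter), so this pair shows no difference that can be told apart from repeated measurement in this assay.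

The three groups on this core differ in more than one substituent at once, so the compounds shown cannot say which fluorine, chlorine or trifluoromethyl substituent accounts for the differences. Also open, from the compounds shown here alone, is how this place responds to an unsubstituted phenyl, a methoxyphenyl, an aminophenyl or a cyclohexyl group.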